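The source may hold more compounds than are shown below. What is called first, only, known or untested is meant among the compounds shown, and "the series" means these compounds.

Two members of the series carry a measured value. Compound 1 `Cc1c(Sc2ccc(Cl)cc2)c(=O)on1C(=O)N1CCCCC1` gives 6 nM in an assay (strain Wistar) for inhibition of Hormone-sensitive lipase (Rattus norvegicus), read by spectrophotometry; a lower number here means a stronger inhibitor, a higher number a weaker inhibitor. Compound 2 `Cc1c(C(C)C)c(=O)on1C(=O)N(C)Cc1ccc(F)cc1` gives 111 nM in this assay, the higher of the two numbers; its nearest neighbour is compound 1, whose number is lower by a margin beyond the scatter. Within the data shown here, the two differ in more than one place, so no single step is set down between them, and the pair shows only that a large spread is possible.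

Compound 3 `Cc1c(C(C)C)c(=O)on1C(=O)N(C)Cc1cccs1` has not yet been measured in this assay. It differs from compound 2 by thiophen-2-yl in place of 4-fluorophenyl on a saturated chain carbon bound to an amide-type nitrogen. Among the measured compounds shown here, no measured step of this kind exists, so the direction is open; the expectation is a step from compound 2 to compound 3 of a 1.1-fold higher number from compound 2 to compound 3 (0.03 log units; within the scatter), that is, none beyond the scatter. Compound 3 is therefore expected to give about 120 nM in this assay, within a range of 40 nM to 360 nM.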

Compound 3, half-maximal inhibitory concentration: 2 nM
Compound 3: the middle estimate sits 60-fold (1.78 log units) above what was measured; the measured number lies below the stated range.
By their numbers in this assay, from the lowest: compound 3; then compound 1; then compound 2.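

In this assay, the group on a saturated chain carbon bound to an amide-type nitrogen is now shown to matter: thiophen-2-yl in place of 4-fluorophenyl gives a 56-fold lower number from compound 2 to compound 3 (1.74 log units; beyond the scatter), with the rest of the structure unchanged. The earlier pair differed in more than one place and showed only a spread, whereas this is a step that can be assigned to one place, though it rests on this single pair. No available measurement bears on the reason for the size of this step.

Left open is whether plain phenyl, furan-2-yl or thiophen-3-yl at this place would match compound 3, which would help separate the loss of the fluorine from the change of ring. Also open, going by these compounds, is how a longer chain in place of the saturated chain carbon would read.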